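Swapping an aromatic heterocycle for a non-aromatic lactam ring

The source may hold more compounds than are shown below. What is called first, only, known or untested is meant among the compounds shown, and "the series" means these compounds.

Among the compounds with values here, in an assay on CHO cells for displacement of a labelled ligand from prostaglandin E2 receptor EP3 subtype (Homo sapiens), read by radioligand binding (on this read-out higher numbers stand for weaker inhibition and lower numbers for stronger inhibition), compound 2 `CC(C)C(c1noc(=O)[nH]1)c1ccc(-c2ccc3cccc(F)c3c2)[nH]c1=O` gives 15 nM, the upper of the two numbers measured so far, while compound 1 `CC(C)C(c1nnc[nH]1)c1ccc(-c2ccc3cccc(F)c3c2)[nH]c1=O` gives 12 nM. Within the data shown here, the single measured step, a 1.3-fold higher number from compound 1 to compound 2 (0.10 log units; within the scatter), traded one five-membered aromatic ring with 3 hetero atoms for another and left the result essentially unchanged. Compound 3 `CC(C)C(/C=C1/CCNC1=O)c1ccc(-c2ccc3cccc(F)c3c2)[nH]c1=O` departs further: a group of 7 heavy atoms (5 carbon, 1 nitrogen, 1 oxygen; one five-membered non-aromatic ring with 1 hetero atom) in place of a group of 6 heavy atoms (2 carbon, 2 nitrogen, 2 oxygen; one five-membered aromatic ring with 3 hetero atoms), on a saturated chain carbon bound to an aromatic carbon and a saturated chain carbon. Among the measured compounds shown here, no measured step covers a five-membered non-aromatic ring with 1 hetero atom entering at this place, so that earlier swap is only a loose guide. Compound 3 is therefore expected to show a modest weakening, a 3.0-fold higher number from compound 2 to compound 3 (0.48 log units; beyond the scatter), with an estimate of 45 nM and a range from 8 nM to 250 nM.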

Compound 3, inhibition constant: 5.3 nM
The estimate for compound 3 lay 8.5-fold (0.93 log units) above the measured number, outside the stated range (below it).
By their numbers in this assay, from the lowest: compound 3; then compounds 1 and 2 (each within the scatter of the next).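

In this assay the five-membered non-aromatic ring with 1 hetero atom brings a 2.8-fold lower number from compound 2 to compound 3 (0.45 log units; beyond the scatter) and a 2.3-fold lower number from compound 1 to compound 3 (0.35 log units; beyond the scatter) which shows that an aromatic ring with 3 hetero atoms is not needed on this saturated chain carbon. Both steps are modest, but unlike the swap between the two aromatic rings, they lie beyond the scatter. Nothing available here explains this gain.

Still open, as far as these compounds go, is whether the lactam ring itself matters, or whether an open-chain amide or a carboxylic acid would serve as well. Also open, from the compounds shown here alone, is how a version of the group without the double bond outside the ring would compare.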